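Ethoxy in Place of Carboxy on the Side Chain

This account rests on a few compounds, and the source may have more. Where it says the series, first, only, none or still open, it means among the compounds named here.

Compound 3 `CCCn1c(=O)n(C)c(=O)c2c1ncn2CCC(=O)O` has been tested in an assay on Cerebral cortex for binding affinity to adenosine receptor A1 (Cavia porcellus), read by radioligand binding; a lower number here means a stronger inhibitor, a higher number a weaker inhibitor. For compound 3 the reading is only a limit of the assay, > 200000 nM, not a number (the limit of > 200000 nM in this assay, at which 1 of the 3 values shown sits). Two related compounds vary a different chain on the shared core: compound 1 `CCCn1c(=O)n(CCCO)c(=O)c2[nH]cnc21` gives 12000 nM, and compound 2 `CCCn1c(=O)n(CCCOC)c(=O)c2[nH]cnc21` gives 12400 nM. Among the measured compounds shown here, the step of a 1.0-fold higher number from compound 1 to compound 2 (0.01 log units; within the scatter) is the only measured step and it concerns another place and a different change, so it offers no direct guide. Compound 4 `CCCn1c(=O)n(C)c(=O)c2c1ncn2CCOCC` differs from compound 3 by ethoxy in place of carboxy on a saturated chain carbon, two bonds along the chain from an aromatic nitrogen. Compound 4 is expected to give a number rather than a limit, estimated at 30000 nM, between 8000 nM and 150000 nM. This estimate corresponds to an expected step of an at least 6.6-fold lower number from compound 3 to compound 4 (0.82 log units; beyond the scatter).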

Compound 4, inhibition constant: 24300 nM
For compound 4 the middle estimate is 1.2-fold (0.09 log units) above the measured one; low and high end bracket the measured number.
By their numbers in this assay, from the lowest: compounds 1, 2 and 4 (each within the scatter of the next, the first and the last beyond it). At a limit, above all of these: compound 3.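

On this side chain, ethoxy in place of carboxy turns a limit into a readable number in this assay, with an at least 8.2-fold lower number from compound 3 to compound 4 (0.91 log units; beyond the scatter). Among the compounds shown here, this is the first measured change at this position, on a saturated chain carbon, two bonds along the chain from an aromatic nitrogen; the earlier step concerned another place. From the compounds shown here alone, compound 3 stands at a limit of the assay, so the step's full size stays unknown: the limit of > 200000 nM in this assay, at which 1 of the 4 values shown sits.

Going by these compounds, what an amine, a methyl ester or a longer chain would give at this position remains open. The compounds shown also leave open whether removing the carboxy or adding the ethoxy matters more.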